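This account rests on a few compounds, and the source may have more. Where it says the series, first, only, none or still open, it means among the compounds named here.

Measured compounds:
compound 1, `Cc1cc(Nc2cc(-c3ccccc3)[nH]n2)n2nc(SCc3c(Cl)cccc3Cl)nc2n1`: 5180 nM
compound 2, `Cc1cc(Nc2cc(-c3ccc(F)cc3)[nH]n2)n2nc(SCc3ccc(Br)cc3)nc2n1`: 6210 nM

In a functional assay on PC-9 cells (Homo sapiens) for inhibition, read by MTT assay, with a stated time of 72 h (on this read-out lower numbers stand for stronger inhibition and higher numbers for weaker inhibition), compound 1 gives 5180 nM and compound 2 gives 6210 nM. The two numbers lie within the usual scatter of each other, so neither compound can be set apart from the other on this read-out; both sit in the micromolar range and the shared core gives only weak inhibition in this setting.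

Compound 3, `Cc1cc(Nc2cc(-c3ccccc3)[nH]n2)n2nc(SCC3CC3)nc2n1`, has not yet been measured in this assay. It keeps the core of compound 1 and differs at one position:

cyclopropyl in place of 2,6-dichlorophenyl on a saturated chain carbon bound to a sulfur

For the measured compounds named here, no pair of measured compounds shows this kind of change, so the size of its effect has to be estimated without a directly matching precedent. Both measured compounds carry a substituted benzyl group on the sulfur, and the data give no case where that group has been replaced by a small saturated ring. For compound 3 the account therefore expects a modest rise in the number, of about a 1.8-fold higher number from compound 1 to compound 3 (0.26 log units; within the scatter), with the possibility that the step stays within the scatter. Compound 3 is estimated at 9500 nM, within a range from 3000 nM to 30000 nM.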

Compound 3, half-maximal inhibitory concentration: > 50000 nM
Compound 3 gave a limit, no number (the forecaster's own chance of this, stated with the estimate: 15%); middle value at least 5.2-fold (0.72 log units) from the limit.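

For the compounds shown here, replacing 2,6-dichlorophenyl with cyclopropyl on a saturated chain carbon bound to a sulfur gives the first readable step at this position: in this assay the change brings an at least 9.6-fold higher number from compound 1 to compound 3 (0.98 log units; beyond the scatter). Both earlier compounds carry a halogenated phenyl ring at this place, so they could not show how much inhibition on this read-out depends on keeping such a ring, and this step shows that the group here can decide whether any inhibition is seen up to the top of the tested range. Compound 3 stands at a limit of the assay and not at a number, so the step gives only a lower bound on its size: the limit of > 50000 nM in this assay, at which 1 of the 3 values shown sits.

The single change removes the aromatic ring, the two chlorine atoms and several heavy atoms together, and the compounds shown cannot say which of these matters. An unsubstituted benzyl group, a cyclohexylmethyl group or a longer chain such as n-hexyl on the sulfur would help to separate them, and an amine or a carboxylic acid on the phenyl ring would extend the comparison further.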